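Fluoromethyl added on the ring carbon: expected lipophilicity shift

The compounds below may be only part of what the source reports. "The series", "measured", "known", "first", "only" and "open" are said of these compounds alone.

For the measured compounds named here, compound 2 `CNC(=O)c1cc(C(=O)NC)c2c(c1)[C@H](c1ccccc1)CO2` stands lowest of the three measured members in a physicochemical assay for lipophilicity, at pH 7.4 (on this read-out lower numbers stand for lower lipophilicity and higher numbers for higher lipophilicity), where compound 2 gives 3.2. Compound 1 `CNC(=O)c1cc(C(=O)NC2CC2)cc2c1O[C@H](CF)[C@H]2c1ccccc1` gives 3.9 and compound 3 `CNC(=O)c1cc(C(=O)N[C@H]2C[C@@H]2C)cc2c1OC[C@H]2c1ccccc1` gives 4.5; both lie beyond the scatter from compound 2. Going by the values given here, the only single-point step among the measured compounds is a number 1.30 log units higher from compound 2 to compound 3 (beyond the scatter), which concerns the amide substituent rather than the ring carbon. Compound 4 `CNC(=O)c1cc(C(=O)NC)c2c(c1)[C@H](c1ccccc1)[C@@H](CF)O2` differs from compound 2 by fluoromethyl in place of hydrogen on a saturated ring carbon. Among the compounds with values here, no measured pair isolates this change: compound 1 carries the fluoromethyl group but also differs from compound 3 at the amide, so the values of compound 1 and compound 3 can only be read as they stand. Without direct precedent, a small upward step in this assay is expected, clearly smaller than the large amide step, and possibly near the edge of the scatter. The step this implies is expected to be a number 0.40 log units higher from compound 2 to compound 4 (beyond the scatter). For compound 4 the estimate in this assay is 3.6, with a range from 3.2 to 4.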

Compound 4, distribution coefficient: 3.3
The estimate for compound 4 lay 0.30 log units above the measured number; low and high end bracket the measured number.
By their numbers in this assay, from the lowest: compounds 2 and 4 (each within the scatter of the next); then compound 1; then compound 3.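

In this assay, fluoromethyl in place of hydrogen on a saturated ring carbon gives a number 0.10 log units higher from compound 2 to compound 4 (within the scatter), so at this position, next to the ring oxygen, the group does not separate the two compounds on this read-out. Methyl in place of cyclopropyl on an amide-type nitrogen gives a number 0.60 log units lower from compound 1 to compound 4 (beyond the scatter), which, together with a number 1.30 log units higher from compound 2 to compound 3 (beyond the scatter), places both steps beyond the scatter at the amide substituent among the compounds shown. Nothing at hand gives a cause for any of these steps.

Open, from the compounds shown here alone, is whether trifluoromethyl, hydroxymethyl or a longer chain on the same ring carbon would also stay within the scatter of compound 2. Also open, going by these compounds, is whether the fluoromethyl step stays as small when the amide carries 2-methylcyclopropyl instead of methyl.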